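Swapping the phenyl arm of an inactive quinolone amide

This account rests on a few compounds, and the source may have more. Where it says the series, first, only, none or still open, it means among the compounds named here.

Compound 1, `O=C(Nc1cccc(C(F)(F)F)c1)c1cc(=O)[nH]c2cc(Br)ccc12`, gives > 20000 nM in a functional assay on KYSE-410 cells (Homo sapiens) for antiproliferative activity, read by MTT assay, with a stated time of 72 h (a lower number here means a stronger inhibitor, a higher number a weaker inhibitor), a limit rather than a number.
Compound 2, `O=C(Nc1cccc(F)c1)c1cc(=O)[nH]c2cc(-c3ccccc3)ccc12`, gives > 20000 nM in this assay, again a limit and not a number.

Compound 2 therefore stands at the top of what this assay can report, and so does compound 1, as the common limit of > 20000 nM in this assay, at which 2 of the 2 values shown sit, shows. Among the measured compounds shown here, nothing measured here separates the two, and no step between them is known. Compound 3, `O=C(Nc1cccc(F)c1)c1cc(=O)[nH]c2cc(-c3ccc(F)c(CO)c3)ccc12`, is the compound still to be measured. The change from compound 2 is 4-fluoro-3-(hydroxymethyl)phenyl in place of phenyl on an aromatic carbon. The new arm carries a hydroxymethyl group and a fluorine where compound 2 carries plain phenyl. With both measured values sitting at a limit, no trend is available to project from, so the expected step from compound 2 to compound 3 is an at least 1.3-fold lower number from compound 2 to compound 3 (0.12 log units; that floor lies within the scatter), most likely none beyond the scatter and quite possibly another limit. For compound 3 the expected value in this assay is 15000 nM, within a range from 3000 nM to 60000 nM.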

Compound 3, half-maximal inhibitory concentration: > 20000 nM
Compound 3: no number, only a limit (the forecaster's own chance of this, stated with the estimate: 60%); at least 1.3-fold (0.12 log units) between middle value and limit.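

Compound 3 also gives only a limit and not a number, so no step can be read between compound 2 and compound 3. All three compounds shown rest on the same limit: the limit of > 20000 nM in this assay, at which 3 of the 3 values shown sit. The compounds shown leave open how strongly any of them acts, and whether 4-fluoro-3-(hydroxymethyl)phenyl in place of phenyl changes antiproliferative activity at all.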